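The source may hold more compounds than are shown below. What is called first, only, known or untested is meant among the compounds shown, and "the series" means these compounds.

Three measured compounds and one that has not yet been measured share the same core and differ only in a single substituent on their six-membered aromatic ring, or in how that ring is joined.

In an assay on isolated protein for inhibition of 2-Hydroxyacid oxidase 2 (Homo sapiens), tested at 1 uM (a lower number here means a weaker effect, a higher number a stronger effect of the compound at the concentration tested), compound 2 `Cc1n[nH]c(C(=O)O)c1Cc1ccc(C(=O)O)cc1` gives 3%. Compound 1 `Cc1n[nH]c(C(=O)O)c1Cc1ccc(C#N)cc1` differs from compound 2 by cyano in place of carboxy on an aromatic carbon, and in this assay compound 1 gives 0%. That change produced the step of a number 3 percentage points lower from compound 2 to compound 1 (within the scatter).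

Compound 3 `Cc1n[nH]c(C(=O)O)c1Cc1cccc(C(=O)O)c1` has the same atoms as compound 2, joined differently; the difference between the two cores is not broken down here. In this assay compound 3 gives 3%, so that all three measured compounds lie within the scatter of one another.

Compound 4 `Cc1n[nH]c(C(=O)O)c1Cc1cccc(C#N)c1` is still to be measured. It differs from compound 3 by cyano in place of carboxy on an aromatic carbon. Among the measured compounds shown here, this is the same kind of change as the one from compound 2 to compound 1, but not the same: in compound 1 the cyano stands para to a large group, in compound 4 it stands meta to a large group.

For compound 4 the expected step is a number 2 percentage points lower from compound 3 to compound 4 (within the scatter), and this expectation rests on the earlier step of the same kind, a number 3 percentage points lower from compound 2 to compound 1 (within the scatter), which stayed within the scatter. The estimate for compound 4 in this assay is therefore 1%, with a range from -8% to 10%.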

Compound 4, a percentage reported as inhibition, at one concentration (the size of the read-out at that concentration, not a potency): 6%
Compound 4: middle estimate off by 5 percentage points, on the low side; the measured number falls inside the stated range.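

In this assay, putting cyano in place of carboxy on an aromatic carbon meta to a large group gave a number 3 percentage points higher from compound 3 to compound 4 (within the scatter), and set beside the earlier case, the two steps do not differ: the same change on two cores in this assay, a number 3 percentage points lower (within the scatter) from compound 2 to compound 1 and a number 3 percentage points higher (within the scatter) from compound 3 to compound 4, 6 percentage points apart, within the scatter of two such steps. Within this small set, then, the swap of carboxy for cyano leaves the read-out within the scatter on both cores, and the two steps give no sign that the place of the group on the aromatic ring matters. This does not show that the change carries a real effect from one core to the other, since the two steps have opposite signs and neither stands clear of the scatter; what agrees here is only the absence of a readable change at a single concentration, which says nothing about potency.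

The compounds shown leave open whether any group in this place, such as an amine, a primary amide or a longer chain, would produce a read-out that stands clear of the scatter. They also leave open whether the swap of carboxy for cyano would still give matching steps on a core where the read-out is well above the values seen here.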